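Ring shrinkage at the amide acyl group of compound 3

The source may report more compounds than this note shows. Statements on the series, on what has been measured and on what is new or still open speak of the compounds shown alone.

Three compounds share a core in which a cyclohexyl diether links a methylsulfonyl pyrazine to a piperidine carrying an acyl or carbamate group. In a functional assay on isolated protein for agonist activity at Glucose-dependent insulinotropic receptor (Rattus norvegicus), read by HTRF and cAMP accumulation (on this read-out higher numbers stand for larger maximal responses and lower numbers for smaller maximal responses), compound 1 `CC(C)(C)OC(=O)N1CCC(O[C@H]2CC[C@H](Oc3cnc(S(C)(=O)=O)cn3)CC2)CC1` gives 110%, compound 2 `CS(=O)(=O)c1cnc(O[C@H]2CC[C@H](OC3CCN(C(=O)Oc4ccccc4)CC3)CC2)cn1` gives 104%, and compound 3 `CS(=O)(=O)c1cnc(O[C@H]2CC[C@H](OC3CCN(C(=O)C4(C(F)(F)F)CCCC4)CC3)CC2)cn1` gives 124%. Compound 3 stands highest of the three: a number 14 percentage points higher from compound 1 to compound 3 (beyond the scatter) and a number 20 percentage points higher from compound 2 to compound 3 (beyond the scatter), while a number 6 percentage points lower from compound 1 to compound 2 (within the scatter).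

Compound 4 `CS(=O)(=O)c1cnc(O[C@H]2CC[C@H](OC3CCN(C(=O)C4(C(F)(F)F)CC4)CC3)CC2)cn1` differs from compound 3 only at the carbonyl carbon, where (a group of 7 heavy atoms (4 carbon, 3 fluorine; one three-membered non-aromatic ring of carbon only) in place of a group of 9 heavy atoms (6 carbon, 3 fluorine; one five-membered non-aromatic ring of carbon only), on a carbonyl carbon).

The two steps that end at compound 3 both concern the group on this carbonyl carbon, and both were modest rises, from a tert-butoxy and from a phenoxy group to the trifluoromethylcyclopentyl. Among the measured compounds shown here, neither step compares two carbocycles of different size, so no measured pair speaks directly to a five-membered ring becoming a three-membered one. The change keeps the trifluoromethyl and the ring and removes only two carbons, a smaller alteration than either measured step. The expectation is therefore a step near or within the scatter, with a slight lean downward because the larger group gave the higher reading in a number 14 percentage points higher from compound 1 to compound 3 (beyond the scatter).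

For compound 4 the expected value in this assay is 116%, with a range from 100% to 132%, which means an expected step of a number 8 percentage points lower from compound 3 to compound 4 (within the scatter).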

Compound 4, largest response reached (Emax), in percent of the reference or control that the assay uses: 140%
Compound 4: middle estimate off by 24 percentage points, on the low side, outside the stated range (above it).
By their numbers in this assay, from the lowest: compounds 2 and 1 (each within the scatter of the next); then compound 3; then compound 4.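

In this assay, among the compounds shown here, the step at this carbonyl carbon is the first to compare two carbocycles of different size, and the smaller ring reads higher with the trifluoromethyl kept: a number 16 percentage points higher from compound 3 to compound 4 (beyond the scatter). Among the compounds shown, the larger group at this place therefore does not give the larger maximal response, and the 1-(trifluoromethyl)cyclopropyl amide also clears both carbamates, with a number 30 percentage points higher from compound 1 to compound 4 (beyond the scatter) and a number 36 percentage points higher from compound 2 to compound 4 (beyond the scatter), which leaves compound 4 highest of the four, with its steps to all the others beyond the scatter. Nothing available on this series accounts for the rise on going to the smaller ring.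

Two ring sizes do not establish a trend with ring size, so a cyclobutyl ring carrying trifluoromethyl could fall between compound 3 and compound 4 or outside them. As far as these compounds go, the part played by the trifluoromethyl itself also stays open, and a methyl or a nitrile in its place on the cyclopropyl ring would address that, while potency remains a separate question from the maximal response read here.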